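Swapping the dimethoxyphenyl ketone for an aminothiophene

A few compounds are considered here, and "the series" means these few. Any claim that something is new, unique, unknown or untested is made for them only; others in the source may bear on it.

Measured compounds:
- compound 1, `COc1ccc(-c2cc3ccccc3nc2/C=C/C(=O)c2ccc(OC)c(OC)c2)cc1`: 6030 nM
- compound 2, `COc1ccc(-c2cc3ccccc3nc2/C=C/C(=O)c2cccs2)cc1`: 1030 nM

In a functional assay on MCF7 cells (Homo sapiens) for antiproliferative activity, read by XTT assay, with a stated time of 72 h (a lower number here means a stronger inhibitor, a higher number a weaker inhibitor), compound 1 stands at the highest of the two numbers, with compound 2 the nearer neighbour through a step of a 5.9-fold lower number from compound 1 to compound 2 (0.77 log units; beyond the scatter). Compound 3, `COc1ccc(-c2cc3ccccc3nc2/C=C/C(=O)c2sccc2N)cc1`, is not yet measured. It differs from compound 1 in one place: 3-aminothiophen-2-yl in place of 3,4-dimethoxyphenyl on a carbonyl carbon. Among the measured compounds shown here, the one step that bears on this is a 5.9-fold lower number from compound 1 to compound 2 (0.77 log units; beyond the scatter), where a thiophen-2-yl replaced the same group on the same carbonyl carbon. A step of similar direction is therefore expected for compound 3, estimated at a 4.0-fold lower number from compound 1 to compound 3 (0.60 log units; beyond the scatter). For the measured compounds named here, the added amino group carries no measured precedent here, so the range is kept wide. Compound 3 is expected to give about 1500 nM, between 400 nM and 6000 nM.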

Compound 3, half-maximal inhibitory concentration: > 10000 nM
Compound 3: a limit, no number; the forecaster's own chance of this, stated with the estimate: 5%; middle value at least 6.6-fold (0.82 log units) from the limit.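

The reading for compound 3 is a limit of this assay, not a number: the limit of > 10000 nM in this assay, at which 1 of the 3 values shown sits.

Among the compounds shown here, the single change of amino in place of hydrogen on an aromatic carbon gives an at least 9.7-fold higher number from compound 2 to compound 3 (0.98 log units; beyond the scatter), so this one group cancels the gain that the thiophene ring alone had brought. Against the 3,4-dimethoxyphenyl ketone the result is an at least 1.6-fold higher number from compound 1 to compound 3 (0.21 log units; that floor lies within the scatter), so compound 3 cannot be placed clearly beyond compound 1.

On these data alone, whether a hydroxyl or a methyl group on that same aromatic carbon would cost as much remains open, as does the true value of compound 3.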